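A Single Ring Swap, Judged Against One Number

This account rests on a few compounds, and the source may have more. Where it says the series, first, only, none or still open, it means among the compounds named here.

In a functional assay on PC-3 cells (Homo sapiens) for cytotoxicity, read by MTT assay, with a stated time of 72 h (a higher number here means a weaker inhibitor, a lower number a stronger inhibitor), compound 1 (`O=C(N/N=C/c1ccc(F)cc1)Nc1cc2c(Nc3ccc(F)c(Cl)c3)ncnc2cc1O[C@H]1CCOC1`) is recorded as "not active" (no number reported) without a number. Among the measured compounds shown here, compound 2 (`O=C(N/N=C/c1cccc(Cl)c1Cl)Nc1cc2c(Nc3ccc(F)c(Cl)c3)ncnc2cc1O[C@H]1CCOC1`) gives 27400 nM as the only number available, so there is no other figure to rank it against. Compound 3 (`O=C(N/N=C/c1ccc(O)c(Br)c1)Nc1cc2c(Nc3ccc(F)c(Cl)c3)ncnc2cc1O[C@H]1CCOC1`) carries 3-bromo-4-hydroxyphenyl in place of 2,3-dichlorophenyl on a carbon with a double bond to nitrogen. For the measured compounds named here, no measured pair shows what such a swap does, so no shift beyond the usual scatter is expected in this assay and the estimated change a 1.4-fold lower number from compound 2 to compound 3 (0.14 log units; within the scatter) stays small. For compound 3 the expected value is 20000 nM with a range from 6000 nM to 60000 nM around it.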

Compound 3, half-maximal inhibitory concentration: 5230 nM
Compound 3: the middle estimate sits 3.8-fold (0.58 log units) above what was measured; measured number below the stated range.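

In this assay, among the compounds shown here, the ring on the carbon with a double bond to nitrogen proves able to move the result: 3-bromo-4-hydroxyphenyl in place of 2,3-dichlorophenyl gives a 5.2-fold lower number from compound 2 to compound 3 (0.72 log units; beyond the scatter) as the first measured step at this position. The swap adds a hydrogen-bond donor and a hydrogen-bond acceptor and exchanges the halogens in one move, so the step cannot be divided among these changes. No measurement at hand explains the gain. Going by these compounds, whether the bromine or the hydroxy group carries the step stays open, as does what an amine or a carboxylic acid on this ring would do.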